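Thiadiazole to chloro-oxazole on a phenylheptanone core

The compounds below may be only part of what the source reports. "The series", "measured", "known", "first", "only" and "open" are said of these compounds alone.

Compound 1 `O=C(CCCCCCc1ccccc1)c1nncs1` is one of three related ketones tested in an assay on HEK-293T cells for inhibition of diacylglycerol lipase-alpha (Homo sapiens), read by colorimetric assay; on this read-out lower numbers stand for stronger inhibition and higher numbers for weaker inhibition. Compound 1 reaches only the limit of > 10000 nM. Compound 2 `O=C(CCCCCCc1ccccc1)c1nnc(-c2ccco2)s1` likewise gives the limit of > 10000 nM. Compound 3 `O=C(CCCCCCc1ccccc1)c1nnc(-c2ccccc2)s1` also stops at the limit of > 10000 nM. Accordingly the steps a step that the two limits leave unreadable from compound 1 to compound 2, a step that the two limits leave unreadable from compound 1 to compound 3 and a step that the two limits leave unreadable from compound 2 to compound 3 cannot be sized, because all three values sit at the limit of > 10000 nM in this assay, at which 3 of the 3 values shown sit. Compound 4 `O=C(CCCCCCc1ccccc1)c1nc(Cl)co1` carries the change (4-chloro-1,3-oxazol-2-yl in place of 1,3,4-thiadiazol-2-yl on a carbonyl carbon). For the measured compounds named here, no measured step touches this ring exchange, so neither direction nor size can be read from the data, and the reasonable expectation for compound 4 is an unchanged step a number no higher from compound 1 to compound 4 (the limit leaves the size open) with wide uncertainty. Compound 4 is therefore estimated at 10000 nM, between 1000 nM and 50000 nM.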

Compound 4, half-maximal inhibitory concentration: 2400 nM
For compound 4 the middle estimate is 4.2-fold (0.62 log units) above the measured one; the measured number falls inside the stated range.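

In this assay, 4-chloro-1,3-oxazol-2-yl in place of 1,3,4-thiadiazol-2-yl on the carbonyl carbon gives an at least 4.1-fold lower number from compound 1 to compound 4 (0.61 log units; beyond the scatter). For the compounds shown here, this is the first change on the shared core that yields a measured number, and its size is only a minimum. Compound 4 alone stands clear of the limit: the limit of > 10000 nM in this assay, at which 3 of the 4 values shown sit.

The step exchanges the ring and brings in chlorine together, so the compounds shown leave the share of each open. Also open, from the compounds shown here alone, is how a plain 1,3-oxazol-2-yl, or a bromine or methyl group in place of the chlorine, would compare.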